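The compounds below may be only part of what the source reports. "The series", "measured", "known", "first", "only" and "open" are said of these compounds alone.

Measured in a functional assay on MCF7 cells (Homo sapiens) for inhibition, read by MTT assay, with a stated time of 48 h; a higher number here means a weaker inhibitor, a lower number a stronger inhibitor:
- Compound 1 `COc1ccc(C(c2c[nH]c3ccc(Br)cc23)c2c[nH]c3ccc(Br)cc23)cc1`: 2300 nM
- Compound 2 `COc1ccc(OC)c(C(c2c[nH]c3ccc(Br)cc23)c2c[nH]c3ccc(Br)cc23)c1`: 2800 nM
- Compound 3 `O=[N+]([O-])c1ccc2[nH]cc(C(c3ccc(Cl)cc3)c3c[nH]c4ccc([N+](=O)[O-])cc34)c2c1`: > 100000 nM

The value for compound 3 is a limit, not a number. Compound 4 `O=[N+]([O-])c1ccc2[nH]cc(C(c3ccc(Br)cc3)c3c[nH]c4ccc([N+](=O)[O-])cc34)c2c1` differs from compound 3 by one swap, (bromo in place of chloro on an aromatic carbon), which is bromo in place of chloro on an aromatic carbon. For the measured compounds named here, only one measured step bears on this, a 1.2-fold higher number from compound 1 to compound 2 (0.09 log units; within the scatter). It also changes the aromatic group on the saturated chain carbon, though with other groups. On that single step, no change beyond the scatter is expected in this assay, and compound 4 may well return only a limit too. The expected step is a number no higher from compound 3 to compound 4 (the limit leaves the size open). Compound 4 is estimated at 100000 nM, with an expected range of 30000 nM to 300000 nM.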

Compound 4, half-maximal inhibitory concentration: > 100000 nM
Compound 4 ended at the assay's limit; the forecaster's own chance of this, stated with the estimate: 70%; the middle value lies on the limit itself.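

Compound 3 and compound 4 both return only a limit, so no step can be read for bromo in place of chloro: the limit of > 100000 nM in this assay, at which 2 of the 4 values shown sit.

The compounds shown leave open whether this swap changes the inhibition at all.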